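Swapping Phenoxy for Oxadiazole on a Shared Imidazopyridine Core

This account rests on a few compounds, and the source may have more. Where it says the series, first, only, none or still open, it means among the compounds named here.

Compound 1, `Fc1cc(F)cc(C2Nc3cccnc3N2C2CCCC2)c1`: 2100 nM
Compound 2, `COc1ccc(-c2nc3cccnc3n2C2CCCCC2)cc1`: 112 nM
Compound 3, `c1ccc(Oc2ccc(-c3nc4cccnc4n3C3CCCC3)cc2)cc1`: > 10000 nM

Of the compounds shown here, three built on the same core have been tested in a functional assay on MDA-MB-231 cells (Homo sapiens) for cytotoxicity, read by MTT assay, with a stated time of 24 h; on this read-out higher numbers stand for weaker inhibition and lower numbers for stronger inhibition. Compound 2 gives 112 nM in this assay, and compound 1 gives 2100 nM. For the measured compounds named here, compound 3 is reported only as a limit of the assay, > 10000 nM, so its true value is not known; it is the one compound at the limit of > 10000 nM in this assay, at which 1 of the 3 values shown sits. On the numbers shown, compound 3 therefore stands at the weak end, with no measured step linking it to compound 1 or compound 2.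

Compound 4, `c1cnc2c(c1)nc(-c1ccc(-c3nnco3)cc1)n2C1CCCC1`, has not yet been measured in this assay. It differs from compound 3 at a single place: 1,3,4-oxadiazol-2-yl in place of phenoxy on an aromatic carbon. The group that leaves is larger than the one that enters, and the one that enters carries more hydrogen-bond acceptors. Going by the values given here, no measured pair isolates this change, so its effect can only be guessed from the spread of the three values. Compound 4 is expected to gain somewhat on compound 3, with the step from the limit being an at least 3.3-fold lower number from compound 3 to compound 4 (0.52 log units; beyond the scatter). The estimate for compound 4 in this assay is 3000 nM, within a range from 500 nM to 20000 nM.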

Compound 4, half-maximal inhibitory concentration: 87 nM
Beside the measured number, compound 4's estimate is 34-fold (1.54 log units) above it; measured number below the stated range.
By their numbers in this assay, from the lowest: compounds 4 and 2 (each within the scatter of the next); then compound 1. At a limit, above all of these: compound 3.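

In this assay, for the compounds shown here, 1,3,4-oxadiazol-2-yl in place of phenoxy, on an aromatic carbon para to a large group, gives an at least 110-fold lower number from compound 3 to compound 4 (2.06 log units; beyond the scatter) and is the first step that can be tied to a single place. The earlier compounds shown here differ from one another in more than one place, so none of them could show that this one position alone can shift the read-out so far. The size of the step has only a lower bound, as compound 3 is a limit of the assay: the limit of > 10000 nM in this assay, at which 1 of the 4 values shown sits.

The compounds shown do not tell whether the gain comes from the arrival of the 1,3,4-oxadiazol-2-yl ring itself or simply from the departure of phenoxy, and a smaller group at the same place, such as a nitrile, a primary amide or a carboxylic acid, would help to separate these two readings. They also leave open whether the same exchange gives a step of similar size when a cyclohexyl group, rather than the cyclopentyl group, sits on the shared core.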